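Swapping the amide-bearing ring for plain piperidine

The source may report more compounds than this note shows. Statements on the series, on what has been measured and on what is new or still open speak of the compounds shown alone.

Measured compounds:
compound 1 `CC(C)C(=O)NC1CCN(c2ccc3cc(NC(=O)CCc4ccc(C(F)(F)F)cc4)ccc3n2)C1` — 90 nM
compound 2 `O=C(CCCCCCCCCCCCc1ccc(C(F)(F)F)cc1)Nc1ccc2nc([N+]34CCC(CC3)CC4)ccc2c1` — 25 nM
compound 3 `O=C(CCc1ccc(C(F)(F)F)cc1)Nc1ccc2nc(N3CC4CC3CO4)ccc2c1` — 70 nM

These three compounds were tested in a functional assay on HEK293 cells for activation of melanin-concentrating hormone receptor 1 (Rattus norvegicus), read by inositol phosphate accumulation; on this read-out lower numbers stand for an effect already at smaller amounts and higher numbers for an effect only at larger amounts of compound. Compound 1 gives the highest number of the three. Its nearest neighbour is compound 3, whose number is within the usual scatter of that of compound 1; compound 2 lies clearly further away, at the lower end.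

The new compound 4 `O=C(CCc1ccc(C(F)(F)F)cc1)Nc1ccc2nc(N3CCCCC3)ccc2c1` differs from compound 1 in one place: piperidin-1-yl in place of 3-((isopropylcarbonyl)amino)pyrrolidin-1-yl on an aromatic carbon. So a ring that carries an amide is replaced by a bare six-membered ring at the same position on the shared core.

Among the measured compounds shown here, only one measured step speaks to this kind of change. From compound 1 to compound 3 the group at the same place was exchanged for a different small bicyclic ring, and the outcome was a 1.3-fold lower number from compound 1 to compound 3 (0.11 log units; within the scatter). That suggests that the group at this position can be varied without a large shift in this assay. Compound 2 shows a lower number, but it also carries a much longer chain on the amide, so it cannot be read as a single step.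

Compound 4 is therefore expected to stay close to compound 1, with a step of about a 1.1-fold higher number from compound 1 to compound 4 (0.05 log units; within the scatter) in this assay. The estimate for compound 4 is 100 nM, with a range from 40 nM to 250 nM.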

Compound 4, half-maximal effective concentration: 110 nM
Compound 4: the middle estimate sits 1.1-fold (0.04 log units) below what was measured; measured number inside the range.
By their numbers in this assay, from the lowest: compound 2; then compounds 3, 1 and 4 (each within the scatter of the next).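

In this assay, the step of a 1.2-fold higher number from compound 1 to compound 4 (0.09 log units; within the scatter) shows that the whole 3-((isopropylcarbonyl)amino)pyrrolidin-1-yl group, with its amide and its hydrogen-bond donor, can give way to a piperidin-1-yl ring with no hydrogen-bond donor while the number stays within the usual scatter. The step of a 1.6-fold higher number from compound 3 to compound 4 (0.20 log units; within the scatter) also stays within the scatter, so three quite different ring groups on this aromatic carbon, one with an amide side group, one bridged and one bare, now give numbers that cannot be told apart in this assay. Nothing measured here offers a reason why these groups read alike.

The compounds shown leave open whether this tolerance extends to a piperidine ring carrying a primary amine or a carboxylic acid, since every group seen at this place so far has no such substituent. They also leave open how the longer chain on the amide of compound 2 would behave with piperidin-1-yl at this place, which would show whether that chain alone goes with a lower number.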